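The compounds below may be only part of what the source reports. "The series", "measured", "known", "first", "only" and "open" are said of these compounds alone.

Compound 1, `COc1cc2nc(C3CCC3)nc(N3CCN(c4ccccc4)CC3)c2cc1OC`, was tested in an in vitro assay on U2OS cells for agonist activity at neurotensin receptor type 2 (Homo sapiens), read by reporter gene assay and beta-arrestin recruitment; a higher number here means that more compound is needed for the effect, a lower number that less compound is needed. In this assay compound 1 reaches only the limit of the assay, > 80000 nM, and not a number. Compound 2, `COc1cc2nc(C3CCC3)nc(N3CCN(c4ccccc4Cl)CC3)c2cc1OC`, differs from compound 1 by chloro in place of hydrogen on an aromatic carbon. In this assay compound 2 also stops at a limit, > 80000 nM, rather than a number. The step that the two limits leave unreadable from compound 1 to compound 2 cannot be read in size, as both values sit at the limit of > 80000 nM in this assay, at which 2 of the 2 values shown sit. Compound 2 thus stands at the limit, with no numerical position to report. Compound 3, `COc1cc2nc(C3CCC3)nc(N3CCN(c4ccccn4)CC3)c2cc1OC`, is not yet measured. It differs from compound 2 by pyridin-2-yl in place of 2-chlorophenyl on an amine nitrogen in a ring. For the measured compounds named here, the only measured step, the one between compound 1 and compound 2, is unreadable, so no measured step gives a size for this change in either direction. Going by the values given here, nothing among the measured compounds suggests that compound 3 would leave the region of the limit. Compound 3 is expected to give 100000 nM in this assay, within 20000 nM to 500000 nM, most likely again reported as a limit. The step that the limit leaves unreadable from compound 2 to compound 3 is expected to be no more than the scatter.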

Compound 3, half-maximal effective concentration: > 80000 nM
Compound 3 gave a limit, no number; the forecaster's own chance of this, stated with the estimate: 85%; the middle value does not contradict the limit.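

Compound 1, compound 2 and compound 3 all stop at a limit and not a number in this assay, so neither the steps among them nor the swap to pyridin-2-yl can be read in size: the limit of > 80000 nM in this assay, at which 3 of the 3 values shown sit.

The compounds shown leave open whether any change to the shared core would yield a measurable value in this assay.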